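Pyrazole series: trifluoromethyl removed from the benzamide end

The source may hold more compounds than are shown below. What is called first, only, known or untested is meant among the compounds shown, and "the series" means these compounds.

Measured so far:
compound 1 `COc1cc(-c2nn(-c3cccc(NC(=O)c4cccc(C(F)(F)F)c4)c3)cc2-c2ccncc2)ccc1Cl`: 4010 nM
compound 2 `COc1cc(-c2nn(-c3cccc(NC(=O)Nc4ccc(Cl)c(Cl)c4)c3)cc2-c2ccncc2)ccc1Cl`: 2130 nM
compound 3 `O=C(Nc1cccc(-n2cc(-c3ccncc3)c(-c3ccc(Cl)c(O)c3)n2)c1)Nc1cc(C(F)(F)F)cc(C(F)(F)F)c1`: 875 nM

In a functional assay on OVCAR-5 cells (Homo sapiens) for inhibition, read by sulforhodamine B assay, with a stated time of 48 h (a lower number here means a stronger inhibitor of growth, a higher number a weaker inhibitor of growth), compound 1 gives 4010 nM, the highest of the three numbers; compound 2 stands nearest, within the scatter, and compound 3 furthest, with its lower number beyond the scatter. Compound 4 `COc1cc(-c2nn(-c3cccc(NC(=O)c4ccccc4)c3)cc2-c2ccncc2)ccc1Cl` differs from compound 1 by hydrogen in place of trifluoromethyl on an aromatic carbon. For the measured compounds named here, the only single-change step in hand, a 1.9-fold lower number from compound 1 to compound 2 (0.27 log units; within the scatter), exchanges the whole aryl amide end for a urea and stays within the scatter. Going by the values given here, no measured step removes a substituent from the benzamide ring, so there is no direct guide. Compounds 1 and 2 only show that this end tolerates change without a shift beyond the scatter. The expected step is a 1.2-fold higher number from compound 1 to compound 4 (0.10 log units; within the scatter), not beyond the scatter. Compound 4 is estimated at 5000 nM, with a range of 2000 nM to 12000 nM.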

Compound 4, concentration for 50% growth inhibition: 15000 nM
The estimate for compound 4 lay 3.0-fold (0.48 log units) below the measured number; measured number above the stated range.
By their numbers in this assay, from the lowest: compound 3; then compounds 2 and 1 (each within the scatter of the next); then compound 4.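

In this assay, for the compounds shown here, the benzamide ring proves sensitive to change at this position: hydrogen in place of trifluoromethyl gives a 3.7-fold higher number from compound 1 to compound 4 (0.57 log units; beyond the scatter) and so moves beyond the scatter, which the earlier compounds did not show. The unsubstituted benzamide also trails the urea end, with a 7.0-fold higher number from compound 2 to compound 4 (0.85 log units; beyond the scatter) on replacing (3,4-dichlorophenyl)amino by phenyl. The data offer no explanation for either step. Open, as far as these compounds go, is whether a nitrile or an amine on this aromatic carbon would recover the number of compound 1, and whether the same loss would appear on the urea end.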